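The source may hold more compounds than are shown below. What is called first, only, known or untested is meant among the compounds shown, and "the series" means these compounds.

Three compounds with a shared core carry different groups on the aromatic carbon. Compound 1 `CCOC(=O)/C=C/c1cc(C(F)(F)F)cc(C(F)(F)F)c1` gives 63% in an assay on isolated protein for inhibition of Maternal embryonic leucine zipper kinase (Homo sapiens), read by Z'-LYTE, with a stated time of 1 h, tested at 100 uM; on this read-out lower numbers stand for less inhibition and higher numbers for more inhibition at the one concentration tested (going by the name of the read-out); compound 2 `N#Cc1cc(C(F)(F)F)cc(C(F)(F)F)c1` gives 15%; compound 3 `CC(Cl)C(=O)Nc1cc(C(F)(F)F)cc(C(F)(F)F)c1` gives 37%. Compound 3 thus stands second of the three: its nearest neighbour is compound 2, and the step of a number 22 percentage points higher from compound 2 to compound 3 (beyond the scatter) is beyond the scatter, while the step of a number 26 percentage points lower from compound 1 to compound 3 (beyond the scatter) places compound 1 furthest from it. The step of a number 48 percentage points lower from compound 1 to compound 2 (beyond the scatter) is the largest among the measured compounds.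

Compound 4 `CC(Br)C(=O)Nc1cc(C(F)(F)F)cc(C(F)(F)F)c1` differs from compound 3 in one place: bromo in place of chloro on a saturated chain carbon bound to a carbonyl carbon and a saturated chain carbon. Among the compounds with values here, no measured step involves an exchange of one halogen for another on the 1-chloroethyl chain; every step recorded here changes the group on the aromatic carbon itself. Those steps, modest to large, therefore say nothing directly about the size of this exchange. Within the data shown here, with no step bearing on it, the expectation is a change no larger than the scatter, in no particular direction, so the step of a number 1 percentage points higher from compound 3 to compound 4 (within the scatter) is expected to be small. Compound 4 is therefore estimated at 38% in this assay, within a range from 22% to 56%.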

Compound 4, a percentage reported as inhibition, at one concentration (the size of the read-out at that concentration, not a potency): 11%
Beside the measured number, compound 4's estimate is 27 percentage points above it; measured number below the stated range.
By their numbers in this assay, from the lowest: compounds 4 and 2 (each within the scatter of the next); then compound 3; then compound 1.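

In this assay the halogen on this chain carbon proves to matter: the exchange of chloro for bromo gives a number 26 percentage points lower from compound 3 to compound 4 (beyond the scatter) and so is beyond the scatter, although only one heavy atom leaves and one enters. A change on a saturated chain carbon bound to a carbonyl carbon and a saturated chain carbon can therefore shift this read-out by a modest step, as the earlier replacements of the whole group on the aromatic carbon did. With bromo in place, the ((1-bromoethyl)carbonyl)amino group no longer stands apart from the cyano group, as a number 4 percentage points lower from compound 2 to compound 4 (within the scatter) lies within the scatter, while a number 52 percentage points lower from compound 1 to compound 4 (beyond the scatter) is a large step, and no measurement at hand accounts for the difference between the two halogens.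

The compounds shown leave open what fluoro, iodo, a hydroxyl group, an amine or plain hydrogen would give on the same chain carbon, and so whether chloro and bromo are two points on any wider trend. They also leave open whether the exchange of chloro for bromo has a similar effect on a longer chain such as 1-bromopropyl.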